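Swapping the bromophenyl for an ethylphenyl on the hydrazide

This account rests on a few compounds, and the source may have more. Where it says the series, first, only, none or still open, it means among the compounds named here.

Compound 1 `CC(C)(C)N(NC(=O)c1ccccc1)C(=O)c1ccccc1F` gives 309 nM in an assay on cells for agonist activity at ecdysone receptor (Bombyx mori), read by a luciferase reporter, with a stated time of 24 h; a lower number here means that less compound is needed, a higher number that more compound is needed for the effect. Compound 2 `CC(C)(C)N(NC(=O)c1cccc(Br)c1)C(=O)c1ccccc1Cl` gives 191 nM in this assay, the lowest of the two numbers, though its gap to compound 1 stays within the scatter. Compound 3 `CCc1ccc(C(=O)NN(C(=O)c2ccccc2Cl)C(C)(C)C)cc1` carries the change (4-ethylphenyl in place of 3-bromophenyl on a carbonyl carbon). Among the measured compounds shown here, no measured pair shows this step, so compound 3 is expected to give a number close to compound 2, with a modest expected move toward a lower value, a 1.6-fold lower number from compound 2 to compound 3 (0.20 log units; within the scatter). Compound 3 is therefore estimated at 120 nM, in a range from 35 nM to 400 nM.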

Compound 3, half-maximal effective concentration: 5.75 nM
The estimate for compound 3 lay 21-fold (1.32 log units) above the measured number; measured number outside the range, below it.
By their numbers in this assay, from the lowest: compound 3; then compounds 2 and 1 (each within the scatter of the next).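

In this assay, 4-ethylphenyl in place of 3-bromophenyl on a carbonyl carbon gives a 33-fold lower number from compound 2 to compound 3 (1.52 log units; beyond the scatter). The number at this place therefore depends strongly on the aryl group it carries, which compound 1 and compound 2 did not show, as they differ in more than one place and their values lie within the scatter. Nothing available explains the size of this step. The compounds shown do not separate the swap of bromine for ethyl from the shift in ring numbering. They also leave open whether a propyl chain or an amine on that ring would keep the number this low.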